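Bromo to Fluoro on the Fused Ring of Compound 3

The source may report more compounds than this note shows. Statements on the series, on what has been measured and on what is new or still open speak of the compounds shown alone.

Measured so far:
- compound 1 `CCOC(=O)c1c(NC(=S)Nc2ccc(C(F)(F)F)cc2)sc2c1CCCC2`: 11900 nM
- compound 2 `CC(C)OC(=O)c1c(NC(=S)Nc2cccc3ccccc23)sc2c1CCCC2`: 140 nM
- compound 3 `CC(C)OC(=O)c1c(NC(=S)Nc2ccc(Br)c3ccccc23)sc2c1CCCC2`: 48 nM

All three were tested in an assay on HEK-Blue hTLR2 cells for agonist activity at Toll-like receptor 2 (Homo sapiens), with a stated time of 24 h; on this read-out lower numbers stand for an effect already at smaller amounts and higher numbers for an effect only at larger amounts of compound. On this read-out compound 3 has the lowest number of the three measured; its nearest neighbour is compound 2, and compound 1 lies far away. Going by the values given here, the only step that differs in one place runs a 2.9-fold lower number from compound 2 to compound 3 (0.46 log units; beyond the scatter), so adding bromo to the fused ring of compound 2 lowered the number by a modest amount.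

Compound 4 `CC(C)OC(=O)c1c(NC(=S)Nc2ccc(F)c3ccccc23)sc2c1CCCC2` is not yet measured. It differs from compound 3 in one place: fluoro in place of bromo on an aromatic carbon. Among the compounds with values here, the only step that bears on this change is the one from compound 2 to compound 3, where a halogen entered the same position. Fluoro is another halogen at that position, so the expectation is a number near compound 3, perhaps drifting back toward compound 2, with the step of a 1.9-fold higher number from compound 3 to compound 4 (0.27 log units; within the scatter) expected to stay within or near the scatter. Compound 4 is therefore estimated at 90 nM, with a range from 30 nM to 300 nM.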

Compound 4, half-maximal effective concentration: 35 nM
The estimate for compound 4 lay 2.6-fold (0.41 log units) above the measured number, within the range that was stated.
By their numbers in this assay, from the lowest: compounds 4 and 3 (each within the scatter of the next); then compound 2; then compound 1.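

In this assay the change from bromo to fluoro gives a 1.4-fold lower number from compound 3 to compound 4 (0.14 log units; within the scatter) and so does not separate these two halogens at this position. Fluoro in place of hydrogen gives a 4.0-fold lower number from compound 2 to compound 4 (0.60 log units; beyond the scatter) and shows that the lower number seen with bromo is not a single case, as two different halogens on this aromatic carbon now go with a number lower than that of hydrogen. Nothing measured here explains why the two halogens give numbers so close to each other.

The compounds shown leave open whether a group that is not a halogen, such as a methoxy group, an amine or a nitrile, would also lower the number at this position. They also leave open whether fluoro would have the same effect with an ethyl ester in place of the isopropyl ester.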